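Cyclic sulfamide series: cytotoxicity on HEL cells

The source may hold more compounds than are shown below. What is called first, only, known or untested is meant among the compounds shown, and "the series" means these compounds.

Measured compounds:
compound 1 `O=C1c2ccccc2N(COCc2ccccc2)S(=O)(=O)N1Cc1ccccc1`: > 50 ug/mL
compound 2 `C#CCOCN1c2ccccc2C(=O)N(Cc2ccccc2)S1(=O)=O`: 50 ug/mL
compound 3 `C#CCOCN1C(=O)c2ccccc2NS1(=O)=O`: > 50 ug/mL

All three were tested in a functional assay on HEL cells (Homo sapiens) for cytotoxicity; on this read-out higher numbers stand for lower toxicity in this test and lower numbers for higher toxicity in this test. In this assay compound 1 gives > 50 ug/mL, which is a limit of the assay rather than a number. Compound 2 gives 50 ug/mL in this assay. Compound 3 gives > 50 ug/mL in this assay, again a limit and not a number.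

Compounds 2 and 1 differ in one place, (phenyl in place of ethynyl on a saturated chain carbon bound to an oxygen on a saturated carbon), and the step of a number no lower from compound 2 to compound 1 (the limit leaves the size open) is open in size, a point that rests on (the limit of > 50 ug/mL in this assay, at which 2 of the 3 values shown sit). The difference between the core of compound 3 and the core of compound 2 is not broken down here.

Compound 4 `O=C1c2ccccc2NS(=O)(=O)N1COCc1ccccc1` has not yet been measured. It stands to compound 3 as compound 1 stands to compound 2: phenyl in place of ethynyl on a saturated chain carbon bound to an oxygen on a saturated carbon, the same change at the same place. Given the step of a number no lower from compound 2 to compound 1 (the limit leaves the size open) and the limit of compound 3, compound 4 is expected to sit at or beyond the same limit, with an expected step that the limit leaves unreadable from compound 3 to compound 4. The estimate for compound 4 is 55 ug/mL, expected to fall between 25 ug/mL and 120 ug/mL.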

Compound 4, minimum cytotoxic concentration: > 50 ug/mL
Compound 4: a limit, no number; the forecaster's own chance of this, stated with the estimate: 70%; the middle value lies beyond the limit too.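

In this assay compound 4 gives > 50 ug/mL as a limit, not a number. No step can be read between compound 3 and compound 4, because compound 3 also stands at a limit: the limit of > 50 ug/mL in this assay, at which 3 of the 4 values shown sit.

The compounds shown leave open how large any effect of propargyl to benzyl is on either core in this assay.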